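Bromo return on the benzyl group of compound 2

The source may report more compounds than this note shows. Statements on the series, on what has been measured and on what is new or still open speak of the compounds shown alone.

Among the measured compounds shown here, in a functional assay on U-251 cells (Homo sapiens) for antiproliferative activity, read by MTT assay, with a stated time of 24 h (a higher number here means a weaker inhibitor, a lower number a stronger inhibitor), compound 2 (`COc1cc(OC)c(-c2coc3cc(OCc4ccc(Cl)cc4)ccc3c2=O)cc1OC`) gives 470 nM, the lowest of the two numbers so far, and compound 1 (`COc1cc(OC)c(-c2coc3cc(OCc4ccc(Br)cc4)ccc3c2=O)cc1OC`) gives 10000 nM. Compound 3 (`COc1cc(OC)c(-c2coc3cc(OCc4ccccc4Br)ccc3c2=O)cc1OC`) carries 2-bromophenyl in place of 4-chlorophenyl on a saturated chain carbon bound to an oxygen on an aromatic ring, with the change on a saturated chain carbon bound to an oxygen on an aromatic ring. For the measured compounds named here, the only measured step bearing on it is the large one for chloro in place of bromo, a 21-fold lower number from compound 1 to compound 2 (1.33 log units; beyond the scatter). Going by the values given here, no measured compound carries the 2-bromophenyl group, so only part of that step is expected to reverse. The expected change is a 5.3-fold higher number from compound 2 to compound 3 (0.73 log units; beyond the scatter), towards a higher number. For compound 3 the estimate is 2500 nM, with an expected range of 500 nM to 10000 nM.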

Compound 3, half-maximal inhibitory concentration: > 10000 nM
Compound 3: only a limit was reported; the forecaster's own chance of this, stated with the estimate: 15%; at least 4.0-fold (0.60 log units) between middle value and limit.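

Replacing 4-chlorophenyl with 2-bromophenyl on a saturated chain carbon bound to an oxygen on an aromatic ring gives an at least 21-fold higher number from compound 2 to compound 3 (1.32 log units; beyond the scatter). The value of compound 3 is a limit of the assay and not a number. Among the compounds shown, activity at this position has a readable value only with 4-chlorophenyl. From the compounds shown here alone, the step from 4-bromophenyl to 2-bromophenyl, a number no lower from compound 1 to compound 3 (the limit leaves the size open), cannot be read, so any effect of moving the bromo stays unknown.

Going by these compounds, the step to 2-bromophenyl changes both halogen and place together, and the share of each remains open. A 2-chlorophenyl group on the same carbon would separate them.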